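Compound 2: 4-fluorophenyl to 4-hydroxyphenyl

This account rests on a few compounds, and the source may have more. Where it says the series, first, only, none or still open, it means among the compounds named here.

In a functional assay on BHK-21 cells (Mesocricetus auratus) for antiproliferative activity, read by sulforhodamine B assay, with a stated time of 48 h, tested at 0.1 uM (a lower number here means less inhibition of growth, a higher number more inhibition of growth at the concentration tested), compound 1 (`O=[N+]([O-])c1cccc(C2=Nn3c(nnc3-c3ccncc3)SC2)c1`) gives 48.2% and compound 2 (`Fc1ccc(OCc2nn3c(-c4ccncc4)nnc3s2)cc1`) gives 43.8%. These two values lie within the scatter of each other. Compound 3 (`Oc1ccc(OCc2nn3c(-c4ccncc4)nnc3s2)cc1`) has hydroxy in place of fluoro on an aromatic carbon. Going by the values given here, no measured pair differs in one place, so the data offer no precedent for this change. No step beyond the scatter is expected in this assay, and neither direction is favoured. The estimated change is a number 1.8 percentage points lower from compound 2 to compound 3 (within the scatter). For compound 3 the expected value is 42%, with an estimated range of 28% to 56%.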

Compound 3, percent growth inhibition at one concentration: 51.6%
For compound 3 the middle estimate is 9.6 percentage points below the measured one, within the range that was stated.
By their numbers in this assay, from the lowest: compounds 2, 1 and 3 (each within the scatter of the next).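

In this assay, the one pair shown that differs in one place gives a number 7.8 percentage points higher from compound 2 to compound 3 (within the scatter) for hydroxy in place of fluoro. This place, on an aromatic carbon para to a large group, therefore takes 4-fluorophenyl to 4-hydroxyphenyl without a step beyond the scatter at the concentration tested. Nothing available bears on a cause for the step.

On these data alone, whether an amine, a methoxy or a carboxylic acid at this place would stay within the scatter remains open. So does whether the same change would behave alike on the core of compound 1.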